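The compounds below may be only part of what the source reports. "The series", "measured", "known", "first", "only" and "open" are said of these compounds alone.

In an ADME assay on HepG2 cells (Homo sapiens) for inhibition, with a stated time of 48 h (on this read-out higher numbers stand for an effect only at larger amounts of compound and lower numbers for an effect already at smaller amounts), compound 1 `C[C@H](C(=O)N1CCCCC1)N1CCN(S(=O)(=O)c2ccc(C(C)(C)C)cc2)CC1` gives only a limit of the assay, > 40000 nM. Compound 2 `CC(C(=O)N1CCCCCC1)N1CCN(S(=O)(=O)c2ccc(C(C)(C)C)cc2)CC1` likewise gives only a limit in this assay, > 40000 nM. Compound 2 thus stands at the limit of > 40000 nM in this assay, at which 2 of the 2 values shown sit, so no numbered value is known for it. Compound 3 `CC(C(=O)N1CCc2ccccc21)N1CCN(S(=O)(=O)c2ccc(C(C)(C)C)cc2)CC1` differs from compound 2 in one place: 2,3-dihydro-1H-indol-1-yl in place of azepan-1-yl on a carbonyl carbon. With both known values at the limit, the step that the limit leaves unreadable from compound 2 to compound 3 is expected to lie within the scatter rather than move in either direction. Compound 3 is therefore estimated at 50000 nM, between 20000 nM and 120000 nM, most likely again reported only as a limit.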

Compound 3, half-maximal effective concentration: > 40000 nM
Compound 3: a limit, no number; the forecaster's own chance of this, stated with the estimate: 85%; the middle value does not contradict the limit.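

For the compounds shown here, compound 2 and compound 3 both give only a limit, so no step between them can be read, because all values shown sit at one limit: the limit of > 40000 nM in this assay, at which 3 of the 3 values shown sit. The compounds shown leave open which group on the carbonyl carbon, if any, would give a numbered value in this assay at all.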